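The source may report more compounds than this note shows. Statements on the series, on what has been measured and on what is new or still open speak of the compounds shown alone.

Working notes on the series. The shared core of compound 1 `C(=C/c1nc2ncccc2[nH]1)\c1ccccc1` carries a styryl arm; in a functional assay on HEp-2 cells (Homo sapiens) for antiproliferative activity, read by MTT assay, with a stated time of 72 h (a lower number here means a stronger inhibitor, a higher number a weaker inhibitor), compound 1 gives 3890 nM. Compound 2 `O=[N+]([O-])c1ccc(Cl)c(/C=C/c2nc3ncccc3[nH]2)c1` adds nitro and chloro to that arm, and in this assay compound 2 gives 49400 nM. Among the compounds with values here, compound 3 `N#Cc1ccc(/C=C/c2nc3ncccc3[nH]2)cc1` carries a nitrile on the arm instead; in this assay compound 3 gives 84900 nM, which places it at the upper end of the three numbers: the value of compound 2 sits within the scatter of it, while a 22-fold higher number from compound 1 to compound 3 (1.34 log units; beyond the scatter) is the one step in the set and is clearly beyond the scatter. Compound 4 `N#Cc1ccc(/C=C/c2nc3ncc(Br)cc3[nH]2)cc1` is the next member. It differs from compound 3 by bromo in place of hydrogen on an aromatic carbon, so the change sits on the core, not on the arm. Within the data shown here, none of the measured steps touches the core, so there is nothing in the set that bears on this change, and no step beyond the scatter is expected. Compound 4 is therefore estimated at 85000 nM, range 28000 nM to 260000 nM, which means an expected step of a 1.0-fold higher number from compound 3 to compound 4 (0.00 log units; within the scatter).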

Compound 4, half-maximal inhibitory concentration: 5690 nM
For compound 4 the middle estimate is 15-fold (1.17 log units) above the measured one, outside the stated range (below it).
By their numbers in this assay, from the lowest: compounds 1 and 4 (each within the scatter of the next); then compounds 2 and 3 (each within the scatter of the next).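

In this assay, within the data shown here, there is a 15-fold lower number from compound 3 to compound 4 (1.17 log units; beyond the scatter), so the shared core is a place where a single change moves the number beyond the scatter, something no earlier step could show. The change is one bromo in place of hydrogen, on an aromatic carbon two atoms from the ring nitrogen, and it runs in the opposite direction to a 22-fold higher number from compound 1 to compound 3 (1.34 log units; beyond the scatter), the step made on the arm. Nothing measured here accounts for the size of the bromo step. The compounds shown do not tell whether bromo at this position gives a comparable step without the nitrile on the arm, as in compound 1. They also leave open whether the step is particular to bromo or extends to chloro, a methyl group or an amine at the same carbon.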